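One Ring Exchanged: From Compound 3 to Compound 4

A few compounds are considered here, and "the series" means these few. Any claim that something is new, unique, unknown or untested is made for them only; others in the source may bear on it.

Of the compounds shown here, three sharing one core have been tested in a functional assay on MCF7 cells (Homo sapiens) for cytotoxicity, read by CellTiter-Glo, with a stated time of 5 days; on this read-out lower numbers stand for stronger inhibition and higher numbers for weaker inhibition. Compound 1 `CC/C(=C(/c1ccc(/C=C/C(=O)O)cc1)c1ccc2[nH]ccc2c1)c1ccccc1` gives 9 nM, compound 2 `CC/C(=C(/c1ccc(/C=C/C(=O)O)cc1)c1ccc2cn[nH]c2c1)c1ccccc1` gives 570 nM, and compound 3 `CC/C(=C(/c1ccc(/C=C/C(=O)O)cc1)c1ccc2[nH]ncc2c1)c1ccccc1C#N` gives 12 nM. Compound 3 thus stands second highest of the three numbers: its gap to compound 1 lies within the scatter, while compound 2 sits far higher. Going by the values given here, the only measured single-place step, a 63-fold higher number from compound 1 to compound 2 (1.80 log units; beyond the scatter), concerns a different part of the molecule. Compound 4 `CC/C(=C(/c1ccc(/C=C/C(=O)O)cc1)c1ccc2[nH]ncc2c1)c1ccncc1Cl` differs from compound 3 in one place: 3-chloropyridin-4-yl in place of 2-cyanophenyl on a double-bonded chain carbon bound to a double-bonded chain carbon and a saturated chain carbon. Among the compounds with values here, no measured step touches this position, so the data give no direction, and the step of a 1.3-fold higher number from compound 3 to compound 4 (0.10 log units; within the scatter) is expected to stay within the scatter. In this assay compound 4 is therefore estimated at 15 nM, most likely between 4 nM and 60 nM.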

Compound 4, half-maximal inhibitory concentration: 4 nM
Estimate against measurement, compound 4: 3.8-fold (0.57 log units) above, within the range that was stated.
By their numbers in this assay, from the lowest: compound 4; then compounds 1 and 3 (each within the scatter of the next); then compound 2.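

In this assay, putting 3-chloropyridin-4-yl in place of 2-cyanophenyl on this double-bonded chain carbon gives a 3.0-fold lower number from compound 3 to compound 4 (0.48 log units; beyond the scatter). Going by these compounds alone, this is the first measured sign that the position responds to a change of group, and it shows that the nitrile is not needed for a low number here. No measurement shown explains this drop.

The ring and its substituent changed together, so the contributions of the ring nitrogen and the chlorine remain unseparated. A 2-chlorophenyl or an unsubstituted pyridin-4-yl group at this position would tell them apart.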